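The source may report more compounds than this note shows. Statements on the series, on what has been measured and on what is new or still open speak of the compounds shown alone.

Compound 1 `CCCCNC(=O)c1c(O)c2cccnc2n(-c2ccccc2)c1=O` carries a butyl group on the amide-type nitrogen of a shared core. In a functional assay on the whole organism for inhibition, with Rattus norvegicus as the target, read by paw edema, at a dose of 100 mg/kg by the oral route (a lower number here means less inhibition, a higher number more inhibition at the dose given (going by the name of the read-out)), compound 1 gives 12.8%, the highest of the three numbers measured. Compound 2 `O=C(NC1CCN(Cc2ccccc2)CC1)c1c(O)c2cccnc2n(-c2ccccc2)c1=O` gives 1.7%, and compound 3 `O=C(NN1CCOCC1)c1c(O)c2cccnc2n(-c2ccccc2)c1=O` gives -8.5%. Among the compounds with values here, the only single-point change measured from compound 1 is a number 21.3 percentage points lower from compound 1 to compound 3 (beyond the scatter), and compound 2 also lies lower than compound 1 by more than the scatter.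

Compound 4 `O=C(Nc1ccccc1)c1c(O)c2cccnc2n(-c2ccccc2)c1=O` differs from compound 1 in one place: phenyl in place of butyl on an amide-type nitrogen. Within the data shown here, no measured step puts a phenyl on this nitrogen, so the expectation rests on what compound 1 shows when its butyl is replaced at all. Among the measured compounds shown here, both replacements seen so far moved the number downward, by a modest amount in the one step that is directly comparable. A small downward step is therefore expected, likely within the scatter, giving a number 4.8 percentage points lower from compound 1 to compound 4 (within the scatter). Compound 4 is estimated at 8%, within a range from -10% to 26%.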

Compound 4, a percentage reported as inhibition, in the whole organism at one dose (the size of the read-out at that dose, not a potency): 4.6%
Beside the measured number, compound 4's estimate is 3.4 percentage points above it; low and high end bracket the measured number.
By their numbers in this assay, from the lowest: compound 3; then compounds 2, 4 and 1 (each within the scatter of the next, the first and the last beyond it).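

Phenyl in place of butyl on the amide-type nitrogen gives a number 8.2 percentage points lower from compound 1 to compound 4 (within the scatter) in this assay, so at this nitrogen the butyl chain and the phenyl ring cannot be told apart in this read-out. Set against morpholin-4-yl, the same phenyl gives a number 13.1 percentage points higher from compound 3 to compound 4 (beyond the scatter), which shows that the fall seen with morpholin-4-yl is not shared by every group put in the place of butyl. Nothing measured here accounts for either step.

The compounds shown leave open whether a longer chain than butyl, or a phenyl carrying a chlorine atom or a methoxy group, would move the number beyond the scatter from compound 1. They also leave open how a carboxylic acid on the butyl chain would read, and a single oral dose says nothing yet about potency.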